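The source may report more compounds than this note shows. Statements on the series, on what has been measured and on what is new or still open speak of the compounds shown alone.

Working notes on the series. In a functional assay on SR cells (Homo sapiens) for inhibition, read by sulforhodamine B assay, with a stated time of 48 h (a lower number here means that less compound is tolerated, a higher number that more compound is tolerated), compound 1 `Nc1cc(N)c2nc(-c3ccccc3)c(Oc3ccc(Cl)c(Cl)c3)nc2c1` gives only a limit, < 100000 nM, so its standing is known as a bound and not as a number; this is the limit of < 100000 nM in this assay, at which 1 of the 3 values shown sits. Compound 2 `CCOC(=O)[C@H](CCC(=O)O)NC(=O)c1ccc(CNc2nc3cc(N)cc(N)c3nc2-c2ccccc2)cc1` gives 93300 nM in this assay. Compound 3 `COc1cc(CNc2nc3cc(N)cc(N)c3nc2-c2ccccc2)cc(OC)c1OC` also returns a limit in this assay, < 50200 nM, which is the limit of < 50200 nM in this assay, at which 1 of the 3 values shown sits. Going by the values given here, all three values of the set sit in the same weak region, and no pair of measured compounds differing in one place is available, so no measured step size can be quoted.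

Compound 4 `Nc1cc(N)c2nc(-c3ccccc3)c(NCc3ccc(F)cc3)nc2c1` differs from compound 1 in one place: (4-fluorobenzyl)amino in place of 3,4-dichlorophenoxy on an aromatic carbon. The site of the change is on an aromatic carbon of a six-membered aromatic ring with 2 nitrogen, part of a fused or bridged system of two rings, next to the ring nitrogen and ortho to a phenyl group of the shared core. With the whole set clustered in the same weak region of this assay, and compound 2 at 93300 nM, no step beyond the scatter is expected from compound 1 to compound 4; the expected step is a step that the limit leaves unreadable from compound 1 to compound 4. Compound 4 is therefore estimated at 80000 nM in this assay, with a range from 30000 nM to 200000 nM, and a limit rather than a number is quite possible.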

Compound 4, concentration lethal to 50% of the cells: < 100000 nM
Compound 4 was reported as a limit; the forecaster's own chance of this, stated with the estimate: 50%; the middle value is on the limit's open side.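

Compound 1 and compound 4 each give only a limit in this assay, so no step can be read between them: the limit of < 100000 nM in this assay, at which 2 of the 4 values shown sit.

The compounds shown leave open whether (4-fluorobenzyl)amino in place of 3,4-dichlorophenoxy on an aromatic carbon changes the tolerated concentration at all.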